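The source may hold more compounds than are shown below. What is called first, only, known or untested is meant among the compounds shown, and "the series" means these compounds.

Values in a functional assay on OVCAR-8 cells (Homo sapiens) for antiproliferative activity; a lower number here means a stronger inhibitor, a higher number a weaker inhibitor:
- Compound 1 `Cn1ncc(Cl)c1-c1cc(C(=O)N[C@@H]2CN[C@H](CCN3CCC(O)CC3)C[C@H]2c2ccc(Cl)c(Cl)c2)oc1Cl`: 15900 nM
- Compound 2 `Cn1ncc(Cl)c1-c1cc(C(=O)N[C@@H]2CN[C@H](CCN3CCCCC3)C[C@H]2c2ccc(Cl)c(Cl)c2)oc1Cl`: 1660 nM
- Compound 3 `Cn1ncc(Cl)c1-c1cc(C(=O)N[C@@H]2CN[C@H](CC(=O)O)C[C@H]2c2ccc(Cl)c(Cl)c2)oc1Cl`: 5120 nM

In this assay, compound 3 is the second highest of the three numbers, with compound 2 lower and compound 1 higher. Compound 4 `Cn1ncc(Cl)c1-c1cc(C(=O)N[C@@H]2CN[C@H](CC(=O)NCC(O)CO)C[C@H]2c2ccc(Cl)c(Cl)c2)oc1Cl` has (2,3-dihydroxypropyl)amino in place of hydroxy on a carbonyl carbon.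

Within the data shown here, no measured step makes this change. The closest guide is a 9.6-fold lower number from compound 1 to compound 2 (0.98 log units; beyond the scatter), where hydrogen replaces hydroxy on a saturated ring carbon. Read in reverse, that single pair links an added hydroxy to a higher number. The steps of a 3.1-fold lower number from compound 1 to compound 3 (0.49 log units; beyond the scatter) and a 3.1-fold higher number from compound 2 to compound 3 (0.49 log units; beyond the scatter) run in opposite directions, so they set no direction for a change at the carboxy group. They do suggest that changes on this chain stay modest.

A modest rise is therefore expected, on thin evidence. The expected step is a 1.6-fold higher number from compound 3 to compound 4 (0.19 log units; within the scatter). For compound 4 the estimated value is 8000 nM, with an expected range of 2500 nM to 25000 nM.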

Compound 4, half-maximal inhibitory concentration: 5900 nM
The estimate for compound 4 lay 1.4-fold (0.13 log units) above the measured number, within the range that was stated.
By their numbers in this assay, from the lowest: compound 2; then compounds 3 and 4 (each within the scatter of the next); then compound 1.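

In this assay, the carboxy group and the (2,3-dihydroxypropyl)carbamoyl group cannot be told apart on this saturated chain carbon (a 1.2-fold higher number from compound 3 to compound 4 (0.06 log units; within the scatter)), so the carbonyl carbon tolerates the larger substituent without a resolved change. Compound 4 also stays separated from both piperidine-bearing compounds (a 3.6-fold higher number from compound 2 to compound 4 (0.55 log units; beyond the scatter); a 2.7-fold lower number from compound 1 to compound 4 (0.43 log units; beyond the scatter)), which places it with compound 3 between them. The link between an added hydroxy and a higher number seen on the saturated ring (a 9.6-fold lower number from compound 1 to compound 2 (0.98 log units; beyond the scatter)) does not carry over to the hydroxy groups of this amide side chain.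

No available data explain this flat result. Still open, going by these compounds, is whether a primary amide, a methyl ester, or a longer chain ending in a carboxylic acid or an amine would match or improve on compound 2 at (1660 nM).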